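Shortening the ether chain on compound 2 to ethyl

A few compounds are considered here, and "the series" means these few. Any claim that something is new, unique, unknown or untested is made for them only; others in the source may bear on it.

Compound 2 `CCCCCCOc1ccc2c(Cl)ccnc2c1` carries a hexyl ether on the shared core. In a functional assay on HCT-116 cells (Homo sapiens) for cytotoxicity, read by MTT assay, with a stated time of 48 h (on this read-out lower numbers stand for stronger inhibition and higher numbers for weaker inhibition), compound 2 gives 2440 nM. Among the three measured compounds it holds the second highest number: its nearest neighbour is compound 1 `CCCCCCCCOc1ccc2c(Cl)ccnc2c1`, whose octyl ether gives 2820 nM, while the furthest is compound 3 `C=CCOc1ccc2c(NCCN(C)C)ccnc2c1`, which bears an allyl ether and an amine in place of the chlorine and gives 860 nM.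

Compound 4 `CCOc1ccc2c(Cl)ccnc2c1` differs from compound 2 by hydrogen in place of butyl on a saturated chain carbon, two bonds along the chain from an oxygen on an aromatic ring. Among the measured compounds shown here, the one measured step that bears on this is a 1.2-fold lower number from compound 1 to compound 2 (0.06 log units; within the scatter), which removed two chain carbons without leaving the scatter. For the measured compounds named here, compound 4 removes four more carbons from the same chain, a larger cut, yet the only evidence at hand is that chain length in this range did not move the number. The step from compound 2 to compound 4 is therefore expected to stay within the scatter, estimated as a 1.1-fold higher number from compound 2 to compound 4 (0.03 log units; within the scatter). Compound 4 is estimated at 2600 nM, with a range from 1200 nM to 6000 nM.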

Compound 4, half-maximal inhibitory concentration: 3160 nM
Beside the measured number, compound 4's estimate is 1.2-fold (0.08 log units) below it; the measured number falls inside the stated range.
By their numbers in this assay, from the lowest: compound 3; then compounds 2, 1 and 4 (each within the scatter of the next).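

Extending the series down to the ethyl ether shows that this position tolerates a much larger cut than the earlier compounds could show. In this assay the change from hexyl to ethyl gives a 1.3-fold higher number from compound 2 to compound 4 (0.11 log units; within the scatter), and the full cut from octyl to ethyl gives a 1.1-fold higher number from compound 1 to compound 4 (0.05 log units; within the scatter). Chain length therefore does not separate the octyl, hexyl and ethyl ethers on the shared core in this read-out, and no evidence at hand bears on this result.

From the compounds shown here alone, it remains open whether a chain ending in a carboxylic acid or an amine on this oxygen would leave the number where it is. Compound 3 differs from these ethers in more than one place, so the compounds shown do not settle how an amine in place of the chlorine would act with an octyl, hexyl or ethyl ether.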